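This account rests on a few compounds, and the source may have more. Where it says the series, first, only, none or still open, it means among the compounds named here.

Working notes on the series. Of the compounds shown here, two of the shared core have been measured. Compound 1 `Nc1nnc(SC[C@H]2O[C@@H](OCc3noc(-c4ccc(Cl)cc4)n3)[C@@H]3OC4(CCCC4)O[C@@H]32)s1` in a functional assay on HeLa cells (Homo sapiens) for antiproliferative activity, read by sulforhodamine B assay, with a stated time of 48 h (a higher number here means a weaker inhibitor of growth, a lower number a stronger inhibitor of growth), gives 16000 nM. Compound 2 `O=[N+]([O-])c1ccc(-c2nc(CO[C@@H]3O[C@H](CO)[C@H]4OC5(CCCC5)O[C@@H]34)no2)cc1` in this assay gives 15000 nM. For the measured compounds named here, the two numbers lie within the scatter of each other, so compound 2 cannot be set apart from compound 1 on these data, and no step between the two is known.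

Compound 3 `Cc1ccc(S(=O)(=O)OC[C@H]2O[C@@H](OCc3noc(-c4ccc([N+](=O)[O-])cc4)n3)[C@@H]3OC4(CCCC4)O[C@@H]32)cc1` is not yet measured. It differs from compound 2 in one place: (4-methylphenyl)sulfonyl in place of hydrogen on an oxygen on a saturated carbon. Going by the values given here, no measured pair shows this change, so the expected size of the step rests only on the structural difference itself. A modest move towards a lower number in this assay is expected, roughly a 1.9-fold lower number from compound 2 to compound 3 (0.27 log units; within the scatter), though a step no larger than the scatter is also possible. Compound 3 is therefore estimated at 8000 nM in this assay, with a range from 2500 nM to 25000 nM.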

Compound 3, concentration for 50% growth inhibition: > 100000 nM
Compound 3: no number, only a limit (the forecaster's own chance of this, stated with the estimate: 15%); middle value at least 12-fold (1.09 log units) from the limit.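

For the compounds shown here, putting (4-methylphenyl)sulfonyl in place of hydrogen on the oxygen of the hydroxymethyl group gives an at least 6.6-fold higher number from compound 2 to compound 3 (0.82 log units; beyond the scatter) in this assay, the first step that can be read and one beyond the scatter. This shows that growth inhibition in the series responds to a change at this position, and that this change moves it towards weaker inhibition. The step gives only a minimum size, as compound 3 reaches a limit of the assay and not a number: the limit of > 100000 nM in this assay, at which 1 of the 3 values shown sits.

As far as these compounds go, whether this outcome belongs to (4-methylphenyl)sulfonyl alone or to any replacement of the hydrogen on this oxygen remains open. A methyl ether, an acetyl group or an amine in place of the hydroxy group at this position would help separate these two readings.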